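The compounds below may be only part of what the source reports. "The series", "measured", "known", "first", "only" and "open" are said of these compounds alone.

Measured so far in a physicochemical assay for solubility, in simulated intestinal fluid, at pH 7.4; on this read-out higher numbers stand for higher solubility and lower numbers for lower solubility:

- compound 1 `Cn1cc(C(=O)Nc2ccc(-c3cccnc3)c(C(F)(F)F)c2)c(=O)c2ccccc21`: 6.7 ug/mL
- compound 2 `Cn1cc(C(=O)Nc2ccc(-c3ccncc3)c(C(F)(F)F)c2)c(=O)c2ccccc21`: 12 ug/mL

With only these two compounds measured, compound 2 at 12 ug/mL stands within the scatter of compound 1, so the numbers do not separate them. The next compound, compound 3 `Cn1cc(C(=O)Nc2ccc(-c3ccccn3)c(C(F)(F)F)c2)c(=O)c2ccccc21`, keeps the shared core of compound 2 and changes only the attached ring: pyridin-2-yl in place of pyridin-4-yl on an aromatic carbon. The pyridin-2-yl enters on the same aromatic carbon, ortho to a trifluoromethyl group and para to a large group.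

Among the compounds with values here, one measured step bears on this change, the exchange of pyridin-3-yl for pyridin-4-yl at that carbon: a 1.8-fold higher number from compound 1 to compound 2 (0.25 log units; within the scatter). Within the data shown here, it stays within the scatter, but it is the only guide, since no measured compound carries a pyridin-2-yl. On this single step, no change beyond the scatter is expected in this assay, and no firm direction can be drawn. The expected step is a 1.5-fold lower number from compound 2 to compound 3 (0.18 log units; within the scatter), an estimate that remains within the scatter. For compound 3 the estimated value is 8 ug/mL, with an expected range from 3 ug/mL to 20 ug/mL.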

Compound 3, solubility: 5.2 ug/mL
The estimate for compound 3 lay 1.5-fold (0.19 log units) above the measured number; the range from low to high includes it.
By their numbers in this assay, from the lowest: compounds 3, 1 and 2 (each within the scatter of the next, the first and the last beyond it).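

In this assay, within the data shown here, pyridin-2-yl in place of pyridin-4-yl, on the aromatic carbon ortho to a trifluoromethyl group and para to a large group, gives the first step to pass beyond the scatter, though only modestly (a 2.3-fold lower number from compound 2 to compound 3 (0.36 log units; beyond the scatter)). The exchange of pyridin-3-yl for pyridin-2-yl at the same carbon stays within the scatter (a 1.3-fold lower number from compound 1 to compound 3 (0.11 log units; within the scatter)), so the numbers do not separate compound 1 and compound 3, and of the three pyridinyl isomers only compound 2 and compound 3 stand apart. No measurement at hand accounts for this difference between the isomers.

Going by these compounds, all three compounds carry a pyridinyl ring at this carbon, so it remains open whether a phenyl ring, a morpholine, or a pyridine bearing an amine or a carboxylic acid would move the number further than the change of ring nitrogen does. On these data alone, it also remains open whether the gap between the pyridin-4-yl and pyridin-2-yl compounds would persist if a chlorine or a methoxy group stood in place of the trifluoromethyl group.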